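Furan-2-yl in Place of Methyl at the Carbonyl Carbon

The compounds below may be only part of what the source reports. "The series", "measured", "known", "first", "only" and "open" are said of these compounds alone.

Of the compounds shown here, two sharing one core have been measured in an assay on CHO cells for displacement of a labelled ligand from adenosine receptor A1 (Homo sapiens), read by scintillation counting, with a stated time of 120 min, tested at 1 uM; a lower number here means less inhibition, a higher number more inhibition at the concentration tested (going by the name of the read-out). Compound 1 `O=C(Nc1nc(-c2ccccc2)nc2cn(-c3ccccc3)nc12)c1ccco1` carries a ((furan-2-yl)carbonyl)amino group and a phenyl group on the core, and in this assay compound 1 gives 11%. Compound 2 `CC(=O)Nc1nc(C)nc2cn(-c3ccccc3)nc12` carries an acetamido group and a methyl group instead, and in this assay compound 2 gives 25%, the higher of the two numbers, with compound 1 standing a distance below it that is beyond the scatter. Since compound 1 and compound 2 differ in two places, the two values alone do not say which difference matters.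

Compound 3 `Cc1nc(NC(=O)c2ccco2)c2nn(-c3ccccc3)cc2n1` has not been measured. It is related to compound 2 by a single change: furan-2-yl in place of methyl on a carbonyl carbon. Compound 3 therefore carries the same ((furan-2-yl)carbonyl)amino group as compound 1 while keeping the methyl group of compound 2.

Compound 3 is expected to land near or somewhat below compound 2, at 20% within 5% to 40%, a step of a number 5 percentage points lower from compound 2 to compound 3 (within the scatter) that may not exceed the scatter.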

Compound 3, a percentage reported as inhibition, at one concentration (the size of the read-out at that concentration, not a potency): 20%
Beside the measured number, compound 3's estimate shows no gap at the digits printed; measured number inside the range.
By their numbers in this assay, from the lowest: compounds 1, 3 and 2 (each within the scatter of the next, the first and the last beyond it).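

In this assay the swap of methyl for furan-2-yl on a carbonyl carbon, with the methyl group of compound 2 kept on the core, gives a number 5 percentage points lower from compound 2 to compound 3 (within the scatter) and so does not stand clear of the scatter in this setting. The other difference can now also be read on its own, since methyl in place of phenyl on an aromatic carbon gives a number 9 percentage points higher from compound 1 to compound 3 (within the scatter) and so neither single change, taken alone, separates itself from repeated measurement. Nothing available here offers an explanation for the size of either step.

Going by these compounds, what stays open is whether a different group on the carbonyl carbon, such as a longer alkyl chain, a cyclohexyl ring or an amine, would move the number beyond the scatter, and whether an ethyl group or a methoxy group on that aromatic carbon would do so. Since each number is the size of the read-out at one concentration, the compounds shown also leave the potency of all three at this receptor undefined.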